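This account rests on a few compounds, and the source may have more. Where it says the series, first, only, none or still open, it means among the compounds named here.

In an assay for inhibition of 3-hydroxy-3-methylglutaryl-coenzyme A reductase (Rattus norvegicus) (on this read-out lower numbers stand for stronger inhibition and higher numbers for weaker inhibition), compound 1 `Cc1cc(C)cc(-c2cc(Cl)cc(Cl)c2/C=C/[C@@H]2C[C@@H](O)CC(=O)O2)c1` gives 13 nM. Compound 2 `Cc1cc(C)c(/C=C/[C@@H]2C[C@@H](O)CC(=O)O2)c(-c2ccc(F)cc2)c1` gives 13 nM, level with compound 1 at the digits shown, and compound 3 `Cc1cc(C)c(/C=C/[C@@H]2C[C@@H](O)CC(=O)O2)c(-c2cc(C)c(F)c(C)c2)c1` gives 10 nM; all three numbers lie within the scatter of one another. Compound 4 `O=C1C[C@H](O)C[C@@H](/C=C/c2c(Cl)cc(Cl)cc2-c2ccc(Cl)c(Cl)c2)O1` differs from compound 1 in one place: 3,4-dichlorophenyl in place of 3,5-dimethylphenyl on an aromatic carbon. Going by the values given here, the only measured step that bears on swapping the aryl ring on this carbon is a 1.3-fold lower number from compound 2 to compound 3 (0.11 log units; within the scatter), where a change of substituents on that ring left the number essentially where it was. Among the compounds with values here, no measured compound carries a 3,4-dichlorophenyl, so the present change is mirrored only in part, and the exchange of two methyl groups for two chloro groups on the ring has no direct precedent here. Because the step of a 1.3-fold lower number from compound 2 to compound 3 (0.11 log units; within the scatter) was small, compound 4 is expected to show a step of a 1.2-fold higher number from compound 1 to compound 4 (0.06 log units; within the scatter) that stays within the scatter. Compound 4 is therefore estimated at 15 nM, with a range from 7 nM to 32 nM.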

Compound 4, half-maximal inhibitory concentration: 25 nM
Estimate against measurement, compound 4: 1.7-fold (0.22 log units) below; low and high end bracket the measured number.
By their numbers in this assay, from the lowest: compounds 3, 1, 2 and 4 (each within the scatter of the next, the first and the last beyond it).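

In this assay, putting 3,4-dichlorophenyl in place of 3,5-dimethylphenyl gives a 1.9-fold higher number from compound 1 to compound 4 (0.28 log units; within the scatter), so this carbon, ortho to a large group, tolerates chloro groups on the aryl ring as well as methyl groups, with a different arrangement of the two substituents. Alongside a 1.3-fold lower number from compound 2 to compound 3 (0.11 log units; within the scatter), this makes two single-place aryl exchanges on this carbon that stay within the scatter, one in each of two different cores, and neither pair goes against that. No measured evidence is available to explain the step.

Still open, going by these compounds, is whether 3,5-dichlorophenyl would behave like 3,4-dichlorophenyl, which would separate the identity of the substituents from their arrangement. Also open, on these data alone, is how this carbon would respond to a cyclohexyl ring, or to an aryl ring bearing an amine or a carboxylic acid.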